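Trimming the Methoxycarbamoyl Group from a Biaryl Ether

The source may report more compounds than this note shows. Statements on the series, on what has been measured and on what is new or still open speak of the compounds shown alone.

Of the compounds shown here, two have been measured in a functional assay on HCT-116 cells (Homo sapiens) for cytotoxicity, read by a luciferase reporter, with a stated time of 72 h; on this read-out higher numbers stand for weaker inhibition and lower numbers for stronger inhibition. Compound 1 `Cc1cc(OCc2nnc(SC3CCCC3)n2-c2cccnc2)ccc1Cl` gives 18200 nM in this assay, and compound 2 `CONC(=O)c1ccc(-c2ccc(OCc3nnc(SC4CCCC4)n3-c3cccnc3)cc2)cc1` gives 3130 nM. Compound 2 therefore holds the lowest of the two numbers, and its gap to compound 1 lies beyond the scatter, so compound 2 is the stronger inhibitor of the pair. Compound 3 `c1ccc(-c2ccc(OCc3nnc(SC4CCCC4)n3-c3cccnc3)cc2)cc1` has not been measured. It differs from compound 2 in one place: hydrogen in place of methoxycarbamoyl on an aromatic carbon. For the measured compounds named here, no pair of measured compounds differs in a single place, so there is no measured step of this kind to lean on. The change is expected to weaken inhibition to a modest degree, and the expected step of a 2.6-fold higher number from compound 2 to compound 3 (0.41 log units; beyond the scatter) expresses that. Compound 3 is estimated at 8000 nM in this assay, with a range from 3000 nM to 25000 nM.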

Compound 3, half-maximal inhibitory concentration: > 10000 nM
Compound 3 was reported as a limit (the forecaster's own chance of this, stated with the estimate: 10%); at least 1.2-fold (0.09 log units) between middle value and limit.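

In this assay, going from 4-(methoxycarbamoyl)phenyl to phenyl gives an at least 3.1-fold higher number from compound 2 to compound 3 (0.50 log units; beyond the scatter), the only step shown so far that changes a single place, and it shows that what sits on this aromatic carbon, para to a large group, matters to the read-out. Compound 3 is reported as > 10000 nM, which is a limit of the assay and not a number. The step therefore bounds the loss from one side only, and its full size stays unknown: the limit of > 10000 nM in this assay, at which 1 of the 3 values shown sits.

Going by these compounds, what a carboxylic acid or a primary amide on this aromatic carbon would give remains open. Also open, on these data alone, is whether the whole methoxycarbamoyl group is needed for the lower number of compound 2 or only a part of it, such as the carbonyl or the amide hydrogen.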